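This account rests on a few compounds, and the source may have more. Where it says the series, first, only, none or still open, it means among the compounds named here.

Compound 1 `Cc1cc(Nc2cc(Cl)cc(Cl)c2)nc(N)n1` and compound 2 `CCc1cc(Nc2cc(Cl)cc(Cl)c2)nc(N)n1` share one core and differ only in a short side chain. In an assay on cells for inhibition of S-adenosylmethionine decarboxylase proenzyme (Homo sapiens), read by mass spectrometry, at pH 7.2, tested at 180 uM (on this read-out lower numbers stand for less inhibition and higher numbers for more inhibition at the one concentration tested (going by the name of the read-out)), compound 1 gives 27%, while compound 2 gives 36%. Of these two numbers, that of compound 1 is the lower, yet the step of a number 9 percentage points higher from compound 1 to compound 2 (within the scatter) stays within the scatter. Compound 3 `Cc1cc(Nc2cc(Cl)cc(Br)c2)nc(N)n1` differs from compound 1 by bromo in place of chloro on an aromatic carbon. For the measured compounds named here, no measured step touches this kind of halogen exchange, and the single step seen, methyl for hydrogen, lies within the scatter, so no change beyond the scatter is expected: a number 3 percentage points higher from compound 1 to compound 3 (within the scatter). Compound 3 is therefore estimated at 30%, ranging from 15% to 45%.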

Compound 3, a percentage reported as inhibition, at one concentration (the size of the read-out at that concentration, not a potency): 33%
The estimate for compound 3 lay 3 percentage points below the measured number; the measured number falls inside the stated range.
By their numbers in this assay, from the lowest: compounds 1, 3 and 2 (each within the scatter of the next).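

Swapping chloro for bromo on this aromatic carbon, meta to a chloro group, gives a number 6 percentage points higher from compound 1 to compound 3 (within the scatter) in this assay. For the compounds shown here, this is the first look at a change on this ring rather than on the short side chain, and this halogen exchange does not separate the two compounds beyond the usual scatter. Nothing available explains the size of this step.

From the compounds shown here alone, it remains open whether an amine, a methoxy group or a carboxylic acid at this position would shift the number beyond the scatter. Going by these compounds, whether the same exchange would behave alike on compound 2 also remains open.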